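Swapping fluoro for chloro on the amide aryl ring

The source may report more compounds than this note shows. Statements on the series, on what has been measured and on what is new or still open speak of the compounds shown alone.

Three related compounds have been tested for their ability to slow the growth of a colon cancer cell line. Compound 1 `CC1=C(C(=O)Nc2ccc(F)c(Cl)c2)C(c2ccccc2Cl)NC(=S)N1` carries a 3-chloro-4-fluorophenyl amide; in a functional assay on COLO 205 cells (Homo sapiens) for cytotoxicity, read by sulforhodamine B assay, with a stated time of 48 h (a higher number here means a weaker inhibitor of growth, a lower number a stronger inhibitor of growth), compound 1 gives 24000 nM. Compound 2 `CC1=C(C(=O)Nc2ccc(F)c(Cl)c2)C(c2cccc(Oc3ccccc3)c2)NC(=S)N1` has a different core; how the cores of compound 1 and compound 2 differ is not broken down here. In this assay compound 2 gives 17800 nM, and compound 3 `CC1=C(C(=O)Nc2ccc(Cl)c(Cl)c2)C(c2cccc(Oc3ccccc3)c2)NC(=S)N1` gives 9330 nM. The change chloro in place of fluoro on an aromatic carbon produced a 1.9-fold lower number from compound 2 to compound 3 (0.28 log units; within the scatter).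

Compound 4 `CC1=C(C(=O)Nc2ccc(Cl)c(Cl)c2)C(c2ccccc2Cl)NC(=S)N1` is not yet measured. It differs from compound 1 by the same change, (chloro in place of fluoro on an aromatic carbon), at the same place on the ring. Within the data shown here, since the one measured example of this change from compound 2 to compound 3 stayed within the scatter, the step from compound 1 to compound 4 is expected to be of similar size, a 1.9-fold lower number from compound 1 to compound 4 (0.28 log units; within the scatter), resting on the single pair available. Compound 4 is therefore estimated at 12500 nM, with a likely range from 6000 nM to 26000 nM.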

Compound 4, concentration for 50% growth inhibition: 7940 nM
The estimate for compound 4 lay 1.6-fold (0.20 log units) above the measured number; measured number inside the range.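

Chloro in place of fluoro, the change from 3-chloro-4-fluorophenyl to 3,4-dichlorophenyl, gives a 3.0-fold lower number from compound 1 to compound 4 (0.48 log units; beyond the scatter) in this assay. Set side by side, the steps on the two cores point the same way and do not differ by more than repeated measurements would: the same change on two cores in this assay, a 1.9-fold lower number (0.28 log units; within the scatter) from compound 2 to compound 3 and a 3.0-fold lower number (0.48 log units; beyond the scatter) from compound 1 to compound 4, 1.6-fold (0.20 log units) apart, within the scatter of two such steps. This suggests that the change carries across these two cores with a similar result, but one of the two steps stays within the scatter on its own, and two pairs in a single cell line cannot show that it would hold on every core in the series or explain why the number drops.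

The compounds shown leave open what other groups would do at this place on the ring, such as bromo, methyl or trifluoromethyl. They also leave open whether the same change would hold on a core whose other aryl ring carries an amine or a carboxylic acid.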